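An Added Methoxy Group Awaiting Its Cytotoxicity Result

The source may report more compounds than this note shows. Statements on the series, on what has been measured and on what is new or still open speak of the compounds shown alone.

In a functional assay on A549 cells (Homo sapiens) for cytotoxicity, read by MTT assay, with a stated time of 72 h (a lower number here means a stronger inhibitor, a higher number a weaker inhibitor), compound 1 (`COc1cccc(/C=C2\CCC/C(=C\c3ccc(OC)c(OC)c3)C2=O)c1`) gives 6700 nM as its reading, and compound 2 (`COc1ccc(/C=C2\CCC/C(=C\c3cc(Cl)cc(Cl)c3)C2=O)cc1OC`) gives 5500 nM as its reading. Going by the values given here, these are the only two numbers so far, and they lie within the scatter of each other, so compound 1 stands level with its sole measured neighbour. Compound 3 (`COc1cc(/C=C2\CCC/C(=C\c3ccc(OC)c(OC)c3)C2=O)cc(OC)c1`) keeps the core of compound 1 and differs from it in one place: methoxy in place of hydrogen on an aromatic carbon with methoxy in place of hydrogen on an aromatic carbon, meta to a large group and meta to a methoxy group. Among the compounds with values here, only one measured step bears on this change, and only indirectly. That step, a 1.2-fold lower number from compound 1 to compound 2 (0.09 log units; within the scatter) alters the same aromatic ring that gains the methoxy group in compound 3, yet it stays small. Within the data shown here, no measured pair isolates the addition of a methoxy group, so the evidence is thin. The expected step in this assay is therefore a 1.3-fold lower number from compound 1 to compound 3 (0.13 log units; within the scatter) and nothing beyond the scatter is foreseen. For compound 3 the estimated value is 5000 nM with an expected range from 2200 nM to 11500 nM at its ends.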

Compound 3, half-maximal inhibitory concentration: 5100 nM
The estimate for compound 3 lay 1.0-fold (0.01 log units) below the measured number; the measured number falls inside the stated range.
By their numbers in this assay, from the lowest: compounds 3, 2 and 1 (each within the scatter of the next).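

Going by these compounds alone, the addition of methoxy in place of hydrogen on an aromatic carbon, meta to a large group and meta to a methoxy group, gives in this assay a 1.3-fold lower number from compound 1 to compound 3 (0.12 log units; within the scatter) and so isolates a single added methoxy group for the first time. The earlier step, a 1.2-fold lower number from compound 1 to compound 2 (0.09 log units; within the scatter) and involving an exchange of the whole 3-methoxyphenyl group for 3,5-dichlorophenyl, could not show what one extra methoxy group does at this place on its own; the new step shows that, in this assay, the change leaves the reading within the scatter of compound 1. Nothing measured on these compounds explains this outcome.

The compounds shown leave open whether an amine or a carboxylic acid on the same aromatic carbon, or a longer chain such as ethoxy in place of the added methoxy group, would move the number beyond the scatter from compound 1. They also leave open whether the same addition would give a similarly small step with 3,5-dichlorophenyl present in the molecule, as it is in compound 2.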